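Working notes: aryl exchange on compound 3

This account rests on a few compounds, and the source may have more. Where it says the series, first, only, none or still open, it means among the compounds named here.

In a functional assay on NPC-TW01 cells (Homo sapiens) for inhibition, read by MTT assay, with a stated time of 72 h (a lower number here means a stronger inhibitor of growth, a higher number a weaker inhibitor of growth), compound 1 `Nc1cc(-c2ccc(Cl)cc2)nn1-c1ccc(Br)cc1` gives 64400 nM as its reading. Compound 2 `CN(C)/C=N/c1c(C=O)c(-c2ccc(Cl)cc2)nn1-c1ccc(Br)cc1` gives > 100000 nM which is a limit and not a number. Compound 3 `CN(C)/C=N/c1cc(-c2ccc(Cl)cc2)nn1-c1cccc(Cl)c1` gives 92700 nM and so stands within the scatter of compound 1. Compound 4 `CN(C)/C=N/c1cc(-c2ccc(Cl)cc2)nn1-c1ccc(Br)cc1` carries 4-bromophenyl in place of 3-chlorophenyl on an aromatic nitrogen, with 4-bromophenyl in place of 3-chlorophenyl on an aromatic nitrogen as the counted difference. Going by the values given here, no measured pair shows this change alone. In this assay no step beyond the scatter is expected, with a 1.3-fold lower number from compound 3 to compound 4 (0.11 log units; within the scatter) as the estimated size of the step. The expectation starts from compound 3 at 92700 nM as the reference. For compound 4 the estimate is 72000 nM with an expected range of 40000 nM to 100000 nM in this read-out.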

Compound 4, concentration for 50% growth inhibition: 60700 nM
The estimate for compound 4 lay 1.2-fold (0.07 log units) above the measured number; measured number inside the range.
By their numbers in this assay, from the lowest: compounds 4, 1 and 3 (each within the scatter of the next). At a limit, above all of these: compound 2.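

In this assay, 4-bromophenyl in place of 3-chlorophenyl on an aromatic nitrogen gives a 1.5-fold lower number from compound 3 to compound 4 (0.18 log units; within the scatter), so this exchange moves the reading no further than the scatter. A group of 5 heavy atoms in place of one nitrogen atom on an aromatic carbon likewise gives a 1.1-fold lower number from compound 1 to compound 4 (0.03 log units; within the scatter). Hydrogen in place of formyl on an aromatic carbon gives an at least 1.6-fold lower number from compound 2 to compound 4 (0.21 log units; that floor lies within the scatter), a step from a limit and so only a floor: the limit of > 100000 nM in this assay, at which 1 of the 4 values shown sits.

This exchange changes the halogen and its place on the phenyl together, so neither can be read alone. Open, on these data alone, is whether a phenyl carrying an amine or a carboxylic acid on this nitrogen would give a step beyond the scatter.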